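Anilino ring substituent survey on the shared core

The source may hold more compounds than are shown below. What is called first, only, known or untested is meant among the compounds shown, and "the series" means these compounds.

Compound 1 `CCOc1ccccc1NC1=CC(=O)c2c(nc3n2[C@H]2OC[C@@H](O)[C@H]2OC3)C1=O` gives 4320 nM in a functional assay on ECa-109 cells for inhibition, with ECa-109 cell line (Homo sapiens) as the target, read by sulforhodamine B assay; on this read-out higher numbers stand for weaker inhibition and lower numbers for stronger inhibition. Compound 2 `O=C1C(Nc2ccccc2)=CC(=O)c2c1nc1n2[C@H]2OC[C@@H](O)[C@H]2OC1` gives 3560 nM and compound 3 `O=C1C(Nc2ccccc2F)=CC(=O)c2c1nc1n2[C@H]2OC[C@@H](O)[C@H]2OC1` gives 2660 nM. Compound 3 stands at the lowest of the three numbers, yet within the scatter of both others: a 1.3-fold lower number from compound 2 to compound 3 (0.13 log units; within the scatter), a 1.6-fold lower number from compound 1 to compound 3 (0.21 log units; within the scatter), and likewise a 1.2-fold lower number from compound 1 to compound 2 (0.08 log units; within the scatter). Compound 4 `O=C1C(Nc2ccc(C(F)(F)F)cc2)=CC(=O)c2c1nc1n2[C@H]2OC[C@@H](O)[C@H]2OC1` differs from compound 3 by 4-(trifluoromethyl)phenyl in place of 2-fluorophenyl on an amine nitrogen. Among the measured compounds shown here, the steps that bear on this change are the three exchanges among the anilino substituents, and none of them moved the number beyond the scatter, so for compound 4 no step beyond the scatter is expected in either direction, a 1.1-fold higher number from compound 3 to compound 4 (0.02 log units; within the scatter). Compound 4 is accordingly estimated at 2800 nM, with a range of 1200 nM to 6500 nM.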

Compound 4, half-maximal inhibitory concentration: 2250 nM
Compound 4: the middle estimate sits 1.2-fold (0.09 log units) above what was measured, and the stated range covers the measured number.
By their numbers in this assay, from the lowest: compounds 4, 3, 2 and 1 (each within the scatter of the next).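

The amine nitrogen of the shared core also accepts 4-(trifluoromethyl)phenyl in this assay without leaving the scatter (a 1.2-fold lower number from compound 3 to compound 4 (0.07 log units; within the scatter)) (a 1.6-fold lower number from compound 2 to compound 4 (0.20 log units; within the scatter)) (a 1.9-fold lower number from compound 1 to compound 4 (0.28 log units; within the scatter)). Across phenyl, 2-fluorophenyl, 2-ethoxyphenyl and 4-(trifluoromethyl)phenyl, no step on this nitrogen separates any two compounds. No supporting data are available to explain this flat result.

Still open, on these data alone, is whether an amine or a carboxylic acid on the aromatic ring would move the number beyond the scatter. A longer alkyl chain in place of the aromatic ring is equally untested in the compounds shown here.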